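The compounds below may be only part of what the source reports. "The series", "measured", "known", "first", "only" and "open" are said of these compounds alone.

Working notes on the series. In a functional assay on MCF7 cells (Homo sapiens) for cytotoxicity, read by MTT assay, with a stated time of 72 h (a lower number here means a stronger inhibitor of growth, a higher number a weaker inhibitor of growth), compound 2 `COc1ccc(CNc2nc([SeH])nc3ccccc23)cc1` gives 94000 nM. Compound 1 `COc1ccc(CNc2nc([Se]C)nc3ccccc23)cc1` gives 98600 nM and compound 3 `CCCCC[Se]c1nc([Se]CCCCC)c2ccccc2n1` gives 95100 nM; all three numbers lie within the scatter of one another, so compound 2 is not set apart. Among the measured compounds shown here, the single one-place step measured, a 1.0-fold lower number from compound 1 to compound 2 (0.02 log units; within the scatter), is within the scatter and concerns a selenium, not the aromatic ring. Compound 4 `CSc1ccc(CNc2nc([SeH])nc3ccccc23)cc1` differs from compound 2 by methylsulfanyl in place of methoxy on an aromatic carbon. For the measured compounds named here, no measured step covers this exchange, and the one step known gives no reason to expect movement, so in this assay no step beyond the scatter is expected. The expected step is a 1.0-fold higher number from compound 2 to compound 4 (0.00 log units; within the scatter). Compound 4 is estimated at 95000 nM, within 40000 nM to 220000 nM.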

Compound 4, concentration for total growth inhibition: > 100000 nM
Compound 4: only a limit was reported; the forecaster's own chance of this, stated with the estimate: 15%; middle value at least 1.0-fold (0.02 log units) from the limit.
By their numbers in this assay, from the lowest: compounds 2, 3 and 1 (each within the scatter of the next). At a limit, above all of these: compound 4.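

In this assay compound 4 gives > 100000 nM, which is a limit of the assay and not a number. This is the first change shown on the aromatic ring: methylsulfanyl in place of methoxy gives an at least 1.0-fold higher number from compound 2 to compound 4 (0.02 log units; that floor lies within the scatter), so the exchange brings no sign of stronger growth inhibition, though its true size stays unknown. The reading joins the series at the assay's limit: the limit of > 100000 nM in this assay, at which 1 of the 4 values shown sits.

Open, as far as these compounds go, is how far compound 4 truly lies from compound 2. Also open is whether another group at this position, such as an amine or a carboxylic acid, would give a number clearly lower than those shown.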